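Adding a nitro group to compound 1

The compounds below may be only part of what the source reports. "The series", "measured", "known", "first", "only" and "open" are said of these compounds alone.

Compound 1 `C/C(=N/NC(=S)Nc1ccccc1)c1ccccn1` gives 6.81 nM
Compound 2 `CC(=NNC(=S)Nc1ccccc1)c1ccccn1` gives 6.8 nM
Compound 3 `C/C(=N/NC(=S)Nc1cccc(I)c1)c1ccccn1` gives 61 nM

All three numbers come from a functional assay on T98G cells (Homo sapiens) for cytotoxicity, read by MTT assay, with a stated time of 48 h; a lower number here means a stronger inhibitor, a higher number a weaker inhibitor. Compound 1 stands level with compound 2 at the low, more potent end of this small set, while compound 3 lies clearly higher.

The next compound to be tested is compound 4 `C/C(=N/NC(=S)Nc1ccc([N+](=O)[O-])cc1)c1ccccn1`, which carries nitro in place of hydrogen on an aromatic carbon, para to a large group: nitro in place of hydrogen on an aromatic carbon.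

Two measured steps are available. The step of a 1.0-fold lower number from compound 1 to compound 2 (0.00 log units; within the scatter) concerns only (the fact that one of compounds 1 and 2 is drawn with a defined configuration and the other without, at the place where they differ), so it says little about a new group. The more relevant one is a 9.0-fold higher number from compound 1 to compound 3 (0.95 log units; beyond the scatter), a modest loss of potency on adding iodo in place of hydrogen on an aromatic carbon. Among the measured compounds shown here, it is a different group and the only such example, so it is a loose guide.

A weaker compound is therefore expected, with an estimated 4.4-fold higher number from compound 1 to compound 4 (0.64 log units; beyond the scatter), somewhat smaller than that iodo step. For compound 4 the estimated value is 30 nM, with an expected range from 6 nM to 150 nM.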

Compound 4, half-maximal inhibitory concentration: 140 nM
For compound 4 the middle estimate is 4.7-fold (0.67 log units) below the measured one; the range from low to high includes it.
By their numbers in this assay, from the lowest: compounds 2 and 1 (each within the scatter of the next); then compound 3; then compound 4.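

In this assay, nitro on an aromatic carbon, para to a large group, brings the largest loss of potency seen in this set: a 21-fold higher number from compound 1 to compound 4 (1.31 log units; beyond the scatter). Among the compounds shown here, the only other added group on the shared core, iodo, gave a smaller step, a 9.0-fold higher number from compound 1 to compound 3 (0.95 log units; beyond the scatter), so both added groups go with a weaker compound, and the compounds with only hydrogen on that ring, compound 1 and compound 2, keep the lowest numbers. Nothing measured here bears on why nitro costs this much.

Two added groups are too few to show whether any group on this ring keeps the potency of compound 1. An amine or a methoxy group in the same place would show whether the loss follows every added group or only some of them.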